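A few compounds are considered here, and "the series" means these few. Any claim that something is new, unique, unknown or untested is made for them only; others in the source may bear on it.

Among the measured compounds shown here, compound 3 `COc1ccc(/C=N/NC(=O)c2ccc(-c3nnc(-c4ccccc4OC)o3)cc2)cc1O` holds the second highest of the three numbers so far. In an ADME assay on THP-1 cells (Homo sapiens) for cytotoxicity (on this read-out lower numbers stand for stronger inhibition and higher numbers for weaker inhibition), compound 3 gives 260000 nM. Compound 1 `COc1ccccc1-c1nnc(-c2ccc(C(=O)N/N=C/c3cccc(F)c3)cc2)o1` gives 353000 nM. Compound 2 `COc1ccccc1-c1nnc(-c2ccc(C(=O)N/N=C/c3cccc(O)c3O)cc2)o1` gives 102000 nM. The change on the carbon with a double bond to nitrogen has given a 1.4-fold lower number from compound 1 to compound 3 (0.13 log units; within the scatter) and a 2.5-fold higher number from compound 2 to compound 3 (0.41 log units; beyond the scatter), while a 3.5-fold lower number from compound 1 to compound 2 (0.54 log units; beyond the scatter) is the only clearly larger movement. Compound 4 `COc1ccccc1-c1nnc(-c2ccc(C(=O)N/N=C/c3ccc(O)cc3)cc2)o1` differs from compound 3 by 4-hydroxyphenyl in place of 3-hydroxy-4-methoxyphenyl on a carbon with a double bond to nitrogen. Two of the three steps at this position stay small, so the expected step is a 1.0-fold lower number from compound 3 to compound 4 (0.02 log units; within the scatter), without a clear direction. Compound 4 is therefore estimated at 250000 nM in this assay, with a range from 110000 nM to 550000 nM.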

Compound 4, half-maximal inhibitory concentration: 261000 nM
For compound 4 the middle estimate is 1.0-fold (0.02 log units) below the measured one, and the stated range covers the measured number.
By their numbers in this assay, from the lowest: compound 2; then compounds 3, 4 and 1 (each within the scatter of the next).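

In this assay, 4-hydroxyphenyl in place of 3-hydroxy-4-methoxyphenyl leaves the number unmoved (a 1.0-fold higher number from compound 3 to compound 4 (0.00 log units; within the scatter)), and 4-hydroxyphenyl in place of 3-fluorophenyl also stays small (a 1.4-fold lower number from compound 1 to compound 4 (0.13 log units; within the scatter)), so compounds 1, 3 and 4 sit together within the scatter. Only the 2,3-dihydroxyphenyl of compound 2 stands apart, now also against 4-hydroxyphenyl (a 2.6-fold higher number from compound 2 to compound 4 (0.41 log units; beyond the scatter)). No supporting data on the cause of this separation are at hand.
Open, going by these compounds, is whether this separation belongs to 2,3-dihydroxyphenyl alone, and how an amine or a carboxylic acid on the phenyl group would read at this position. Changes elsewhere on the shared core also remain open.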